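The source may hold more compounds than are shown below. What is called first, only, known or untested is meant among the compounds shown, and "the series" means these compounds.

Within the data shown here, compound 1, `CCCc1nc(CC)c(C(=O)OCCCOCc2ccccc2)n1Cc1ccc(-c2ccccc2S(=O)(=O)NC(=O)OCCC(C)C)cc1F`, is one of three compounds measured in an assay on isolated protein for binding affinity to Type-2 angiotensin II receptor (Homo sapiens); on this read-out higher numbers stand for weaker inhibition and lower numbers for stronger inhibition. In this assay compound 1 gives 2 nM, the second highest of the three numbers. Its nearest neighbour is compound 3, `CCCCOC(=O)NS(=O)(=O)c1ccccc1-c1ccc(Cn2c(CCC)nc(CC)c2C(=O)OCc2ccccc2C(=O)c2ccccc2)c(F)c1`, which in this assay gives 0.9 nM, a number that lies beyond the scatter below that of compound 1. The furthest is compound 2, `CCCCN(Cc1ccccc1)C(=O)c1ccc(COC(=O)c2c(CC)nc(CCC)n2Cc2ccc(-c3ccccc3-c3nn[nH]n3)cc2)cc1`, which in this assay gives 200 nM, far beyond the scatter above compound 1.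

The new compound 4, `CCCc1nc(CC)c(C(=O)OCCC[S+]([O-])c2ccccc2)n1Cc1ccc(-c2ccccc2S(=O)(=O)NC(=O)OCCC(C)C)cc1F`, differs from compound 1 in one place: a group of 8 heavy atoms (6 carbon, 1 oxygen, 1 sulfur; one six-membered aromatic ring of carbon only) in place of a group of 8 heavy atoms (7 carbon, 1 oxygen; one six-membered aromatic ring of carbon only), on a saturated chain carbon, three bonds along the chain from an oxygen next to a carbonyl group. The shared core of compound 1 and compound 4, with the sulfonylcarbamate and the fluorinated biaryl part, is kept unchanged; only the group at the end of the ester chain is exchanged, a benzyloxy group leaving and a group of six carbons, one oxygen and one sulfur with one six-membered aromatic ring of carbon only entering.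

Among the measured compounds shown here, no measured pair shows this exchange, so its effect is not known from the data. Given that the rest of compound 4 is identical to compound 1, the step from compound 1 to compound 4 is expected to be small, at a 1.5-fold higher number from compound 1 to compound 4 (0.18 log units; within the scatter), and not clearly beyond the scatter in either direction. Compound 4 is therefore estimated to give 3 nM in this assay, with a range from 1 nM to 10 nM.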

Compound 4, half-maximal inhibitory concentration: 1 nM
The estimate for compound 4 lay 3.0-fold (0.48 log units) above the measured number; low and high end bracket the measured number.
By their numbers in this assay, from the lowest: compounds 3, 4 and 1 (each within the scatter of the next, the first and the last beyond it); then compound 2.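

Among these compounds, compounds 1 to 3 contained no pair differing in one place, so this is the first direct reading of any single change among them. On a saturated chain carbon, three bonds along the chain from an oxygen next to a carbonyl group, replacing benzyloxy with the sulfur-containing group gives a 2.0-fold lower number from compound 1 to compound 4 (0.30 log units; within the scatter) in this assay, so the two compounds cannot be told apart on this read-out. This position therefore accepts this exchange of one end group for another with the same heavy-atom count, the same six-membered aromatic ring of carbon only and the same hydrogen-bond donor and acceptor counts, without a change beyond the scatter, and nothing available explains this result.

The compounds shown leave open whether the same holds for end groups of a different kind at this place, such as an amine, a carboxylic acid or a plain alkyl chain without a ring. They also leave open what a longer chain between the ester oxygen and the end group would do, and whether this exchange would give a similar step on another core.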